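Chain-extended dicarboxylic acid glycosides: inhibition on leukaemia cells

The compounds below may be only part of what the source reports. "The series", "measured", "known", "first", "only" and "open" are said of these compounds alone.

Compound 1 `CC1OC(OC2CCCCC2OCCCC(C(=O)O)C(=O)O)C(O)C(O)C1O`, compound 2 `CC1OC(OC2CCCCC2OCCCCCC(C(=O)O)C(=O)O)C(O)C(O)C1O` and compound 3 `CC1OC(OC2CCCCC2OCCCCCCCCC(C(=O)O)C(=O)O)C(O)C(O)C1O` share a core and differ in the chain that carries the two carboxylic acids; compound 4 `CC1OC(OC2CCCCC2OCCCCCCCCCCC(C(=O)O)C(=O)O)C(O)C(O)C1O` continues the series and has not been measured. In a functional assay on HL-60 cells (Homo sapiens) for inhibition (a higher number here means a weaker inhibitor, a lower number a stronger inhibitor), compound 1 gives > 5000000 nM, which is a limit of the assay and not a number. Compound 2 likewise gives only a limit, > 5000000 nM. Compound 3 also stays at a limit, > 5000000 nM. The change 3,3-dicarboxypropyl in place of dicarboxymethyl on a saturated chain carbon, three bonds along the chain from an oxygen on a saturated carbon gives a step that the two limits leave unreadable from compound 1 to compound 2, and the step that the two limits leave unreadable from compound 2 to compound 3 is equally unreadable, since all three values sit at the limit of > 5000000 nM in this assay, at which 3 of the 3 values shown sit. The difference between the cores of compound 1 and compound 3 is not broken down here. From compound 3 to compound 4 the same kind of change is made, (3,3-dicarboxypropyl in place of dicarboxymethyl on a saturated chain carbon, eight bonds along the chain from an oxygen on a saturated carbon); the place differs in that the group now sits eight bonds along the chain from an oxygen on a saturated carbon rather than three. With every measured value at the limit of > 5000000 nM in this assay, at which 3 of the 3 values shown sit, compound 4 is expected to remain at that limit, so the expected step that the limit leaves unreadable from compound 3 to compound 4 is not readable as a size either. Compound 4 is estimated at 8000000 nM, with an expected range from 3000000 nM to 30000000 nM.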

Compound 4, half-maximal inhibitory concentration: > 5000000 nM
Compound 4 ended at the assay's limit; the forecaster's own chance of this, stated with the estimate: 90%; the middle value lies beyond the limit too.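

In this assay compound 4 gives > 5000000 nM, a limit of the assay and not a number. No size can be read for the change from compound 3 to compound 4, and the whole series rests at one value: the limit of > 5000000 nM in this assay, at which 4 of the 4 values shown sit.

The compounds shown leave open whether any chain length here gives measurable inhibition.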